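The compounds below may be only part of what the source reports. "The series", "measured", "known", "first", "only" and "open" are said of these compounds alone.

Measured in an ADME assay on HepG2 cells (Homo sapiens) for cytotoxicity, with a stated time of 72 h; a lower number here means that less compound is needed, a higher number that more compound is needed for the effect:
Compound 1 `Cc1cc(NC(=O)Nc2ccccc2N)c2ccccc2n1`: > 25000 nM, a limit.
Compound 2 `Cc1cc(NC(=O)Nc2ccc(O)cc2)c2ccccc2n1`: > 25000 nM, a limit.

For the measured compounds named here, compound 2 stands only at a limit, without a number, and the one other value shown is also a limit. Compound 3 `Cc1cc(NC(=O)Nc2cccnc2)c2ccccc2n1` carries pyridin-3-yl in place of 4-hydroxyphenyl on an amide-type nitrogen. Going by the values given here, the only measured step bearing on this is a step that the two limits leave unreadable from compound 1 to compound 2. Compound 1 and compound 2 share (the limit of > 25000 nM in this assay, at which 2 of the 2 values shown sit). With no size to carry over, no step beyond the scatter is expected in this assay. The estimated step is a step that the limit leaves unreadable from compound 2 to compound 3. Compound 3 is expected at 30000 nM, with an estimated range of 12000 nM to 60000 nM.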

Compound 3, half-maximal effective concentration: > 25000 nM
Compound 3: a limit, no number; the forecaster's own chance of this, stated with the estimate: 85%; the middle value is on the limit's open side.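

No step can be read among compound 1, compound 2 and compound 3, which share one limit: the limit of > 25000 nM in this assay, at which 3 of the 3 values shown sit.

Still open, going by these compounds, is whether any of the three reaches a number in this assay and whether their groups on the amide-type nitrogen differ at all.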